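The compounds below may be only part of what the source reports. "The series", "measured", "known", "first", "only" and "open" are said of these compounds alone.

Three compounds of the series, sharing one core, have been measured in an assay (Rattus norvegicus) for inhibition of Fatty-acid amide hydrolase 1 (Homo sapiens); on this read-out lower numbers stand for stronger inhibition and higher numbers for weaker inhibition. Compound 1 `COC(=O)c1ccc(-c2cnc(C(=O)CCCCCCc3ccccc3)o2)cc1` gives 40 nM. Compound 2 `O=C(CCCCCCc1ccccc1)c1ncc(-c2ccc(F)cc2)o1` gives 62 nM. Compound 3 `O=C(CCCCCCc1ccccc1)c1ncc(-c2ccc(O)cc2)o1` gives 140 nM, the highest of the three numbers: the gap is a 3.5-fold higher number from compound 1 to compound 3 (0.54 log units; beyond the scatter) and a 2.3-fold higher number from compound 2 to compound 3 (0.35 log units; beyond the scatter), both beyond the scatter, whereas a 1.6-fold higher number from compound 1 to compound 2 (0.19 log units; within the scatter) stays within it.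

Compound 4 `NS(=O)(=O)c1ccc(-c2cnc(C(=O)CCCCCCc3ccccc3)o2)s1` is next, not yet measured. Its change from compound 3 is 5-sulfamoylthiophen-2-yl in place of 4-hydroxyphenyl on an aromatic carbon. For the measured compounds named here, all three measured steps concern the same position on the core, but each swaps only a group on the 4-hydroxyphenyl; none swaps the whole ring, so there is no direct precedent. What the steps do show is that changes at this position move the number only modestly, and that the hydroxy compound sits at the weak end. A departure from the hydroxy end is therefore expected to bring the number back toward the range of compounds 1 and 2, giving a step of about a 2.3-fold lower number from compound 3 to compound 4 (0.37 log units; beyond the scatter) for compound 4, as a modest lowering rather than a large one. Compound 4 is accordingly estimated at 60 nM, with a range from 15 nM to 250 nM, the uncertainty being wider than usual since the ring itself is exchanged.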

Compound 4, inhibition constant: 3 nM
Compound 4: middle estimate off by 20-fold (1.30 log units), on the high side; measured number below the stated range.
By their numbers in this assay, from the lowest: compound 4; then compounds 1 and 2 (each within the scatter of the next); then compound 3.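

In this assay, the position on an aromatic carbon next to the ring oxygen proves far more responsive than the earlier swaps on the phenyl ring suggested: those steps were modest or within the scatter, whereas a 47-fold lower number from compound 3 to compound 4 (1.67 log units; beyond the scatter) and a 21-fold lower number from compound 2 to compound 4 (1.32 log units; beyond the scatter) are both large. For the compounds shown here, the earlier compounds changed only a single group on a retained six-membered aromatic ring, so they gave no sign that exchanging the whole aryl unit for 5-sulfamoylthiophen-2-yl could lower the number this far, and the ceiling they implied for this position no longer holds. No measurement shown here bears on why this change has so large an effect.

In 5-sulfamoylthiophen-2-yl the five-membered aromatic ring and the sulfamoyl group enter together, so the compounds shown cannot say which of the two carries the step; 4-sulfamoylphenyl and an unsubstituted thiophen-2-yl at the same place would separate them. Also open, as far as these compounds go, is how specific the result is to the sulfamoyl group, for instance whether a carboxylic acid or a methylsulfonyl group on the same ring would give a comparable number, and whether the step holds with a shorter chain on the carbonyl.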